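Cyclohexyloxy in place of methoxy on the shared core

This account rests on a few compounds, and the source may have more. Where it says the series, first, only, none or still open, it means among the compounds named here.

Compound 2 `COc1ccc2ncc(-c3nn[nH]n3)cc2c1` has been tested only in a functional assay on the whole organism (strain Sprague-Dawley) for inhibition, with Rattus norvegicus as the target; a higher number here means that more compound is needed for the effect, a lower number that less compound is needed. In this assay compound 2 gives > 25 mg/kg, and this is a limit of the assay, not a number. Compound 1 `Fc1ccc2ncc(-c3nn[nH]n3)cc2c1`, the fluoro analogue on the shared core, gives 50 mg/kg in this assay. The step that the limit leaves unreadable from compound 1 to compound 2 cannot be sized because the limit of > 25 mg/kg in this assay, at which 1 of the 2 values shown sits, leaves the position of compound 2 unread; the two compounds may sit within the scatter of each other or apart.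

Compound 3 `c1cc2ncc(-c3nn[nH]n3)cc2cc1OC1CCCCC1` differs from compound 2 by cyclohexyl in place of methyl on an oxygen on an aromatic ring. Within the data shown here, no measured step touches the group on the oxygen, so none of the measured steps bears on this change, and compound 2 itself stands only at a limit. Without a reference step, the step that the limit leaves unreadable from compound 2 to compound 3 in this assay is expected to lie within the scatter. Compound 3 is therefore estimated at 40 mg/kg, with a range from 12 mg/kg to 130 mg/kg, and a fair chance that this assay again reports only a limit.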

Compound 3, minimum effective dose: 10 mg/kg
Beside the measured number, compound 3's estimate is 4.0-fold (0.60 log units) above it; measured number below the stated range.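

The oxygen on the aromatic ring accepts a far larger group than methyl: in this assay, cyclohexyl in place of methyl gives an at least 2.5-fold lower number from compound 2 to compound 3 (0.39 log units; beyond the scatter), so less compound is needed for the effect. Against the fluoro analogue, the swap on the aromatic carbon gives a 5.0-fold lower number from compound 1 to compound 3 (0.70 log units; beyond the scatter), which makes this the series' one step with a readable size, since the fluoro-to-methoxy step cannot be read. The step from the methoxy compound gives only a minimum size and not a full one because of a limit on compound 2: the limit of > 25 mg/kg in this assay, at which 1 of the 3 values shown sits.

Open, from the compounds shown here alone, is whether the lower number depends on the six-membered ring of the cyclohexyl or on the carbon count of the group on the oxygen, which an open chain such as n-hexyl on the same oxygen would separate. Also open, going by these compounds, is how far the position extends in this assay, for instance to a phenyl ring, a benzyl group or a chain ending in an amine or a carboxylic acid.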